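Trifluoromethyl for chloro: a step not yet measured

The source may report more compounds than this note shows. Statements on the series, on what has been measured and on what is new or still open speak of the compounds shown alone.

Of the compounds shown here, two have been measured so far in a functional assay on MGC-803 cells (Homo sapiens) for inhibition, read by MTT assay, with a stated time of 72 h; a lower number here means a stronger inhibitor, a higher number a weaker inhibitor.

Compound 1 `COc1ccc(N2CCCC2)c(C(=O)Nc2ccc(CNC(=O)OCc3cccnc3)cc2)c1` gives 85700 nM
Compound 2 `O=C(NCc1ccc(NC(=O)c2cc(Cl)ccc2N2CCCC2)cc1)OCc1cccnc1` gives 55500 nM

These two values lie within the scatter of each other, so compound 2, at 55500 nM, cannot be ranked apart from compound 1. The next compound, compound 3 `O=C(NCc1ccc(NC(=O)c2cc(C(F)(F)F)ccc2N2CCCC2)cc1)OCc1cccnc1`, carries trifluoromethyl in place of chloro on an aromatic carbon, meta to a large group and para to a pyrrolidin-1-yl group: trifluoromethyl in place of chloro on an aromatic carbon.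

Going by the values given here, one measured step bears on this change, and it concerns the same aromatic carbon. It is a 1.5-fold lower number from compound 1 to compound 2 (0.19 log units; within the scatter), with chloro in place of methoxy. That step stayed within the scatter, but it is a single step and involves no trifluoromethyl group, so the support is thin. No step beyond the scatter is therefore expected in this assay, and no direction can be favoured with confidence.

The expected change is a 1.1-fold lower number from compound 2 to compound 3 (0.05 log units; within the scatter).

For compound 3 the estimated value is 50000 nM, with an expected range from 22000 nM to 110000 nM.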

Compound 3, half-maximal inhibitory concentration: 42100 nM
Compound 3: the middle estimate sits 1.2-fold (0.07 log units) above what was measured; low and high end bracket the measured number.
By their numbers in this assay, from the lowest: compounds 3, 2 and 1 (each within the scatter of the next, the first and the last beyond it).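

In this assay, the aromatic carbon para to the pyrrolidin-1-yl group now carries a third group, and trifluoromethyl, with 4 heavy atoms, takes the place of chloro, with 1, in a 1.3-fold lower number from compound 2 to compound 3 (0.12 log units; within the scatter); compound 2 and compound 3 therefore cannot be ranked apart, and this carbon accommodates the larger group without a step beyond the scatter. The earlier compounds shown here showed no step beyond the scatter at this carbon, whereas trifluoromethyl in place of methoxy gives a 2.0-fold lower number from compound 1 to compound 3 (0.31 log units; beyond the scatter), a modest step and the first at this position to pass the scatter, although each of the two shorter steps along the same series stays within it. No measurement available here accounts for either step.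

The compounds shown leave open whether a nitrile, an amine or a carboxylic acid on this same carbon would give a number clearly apart from those of compound 2 and compound 3. They also leave open whether the modest step from methoxy to trifluoromethyl would persist if the pyrrolidin-1-yl group were replaced by a piperidine or a morpholine.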